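The source may hold more compounds than are shown below. What is called first, only, known or untested is meant among the compounds shown, and "the series" means these compounds.

Measured so far:
- compound 1 `Cc1ccc(NC(=O)/C=C/c2ccccc2)c(C(N)=O)c1` - "not determined" (no result reported)
- compound 2 `NC(=O)c1cc(I)ccc1NC(=O)/C=C/c1ccccc1` - 347 nM

Among the compounds with values here, in a functional assay on RPMI-8226 cells (Homo sapiens) for inhibition, read by sulforhodamine B assay, with a stated time of 48 h (on this read-out higher numbers stand for weaker inhibition of growth and lower numbers for stronger inhibition of growth), compound 2 gives 347 nM as the only number, while compound 1 has no result reported. Compound 3 `NC(=O)c1cc(I)ccc1NC(=O)/C=C/c1ccccc1Cl` differs from compound 2 by chloro in place of hydrogen on an aromatic carbon, with chloro in place of hydrogen on an aromatic carbon, ortho to a large group. Within the data shown here, no measured step is available as a guide, so no shift beyond the scatter is expected in this assay in either direction. The expected change is a 1.2-fold lower number from compound 2 to compound 3 (0.06 log units; within the scatter) in this estimate. Compound 3 is estimated at 300 nM, with an expected range of 100 nM to 900 nM here.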

Compound 3, concentration for 50% growth inhibition: 772 nM
Compound 3: the middle estimate sits 2.6-fold (0.41 log units) below what was measured; low and high end bracket the measured number.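

In this assay, chloro in place of hydrogen on an aromatic carbon, ortho to a large group, gives a 2.2-fold higher number from compound 2 to compound 3 (0.35 log units; beyond the scatter). This first readable step in the series shows that this position is not indifferent to substitution: going from phenyl to 2-chlorophenyl weakens inhibition of growth modestly. Nothing available on this result accounts for the shift.

From the compounds shown here alone, whether fluoro, methoxy or an amine at the same position would move the number in the same direction remains open. A single step also leaves open whether chloro elsewhere on this ring would behave alike.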